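Cyclopropylamino for chloropropyl on the carbonyl

The compounds below may be only part of what the source reports. "The series", "measured", "known", "first", "only" and "open" are said of these compounds alone.

Compound 3 `O=C(CCCCl)Nc1ccc(S(=O)(=O)Oc2ccccc2I)cc1` gives 7200 nM in a functional assay on M21 cells (Homo sapiens) for antiproliferative activity, read by sulforhodamine B assay, with a stated time of 48 h (on this read-out lower numbers stand for stronger inhibition and higher numbers for weaker inhibition), the second highest of the three numbers measured; compound 1 `CCCCCC(=O)Nc1ccc(S(=O)(=O)Oc2ccccc2I)cc1` gives 11000 nM and compound 2 `O=C(CCl)Nc1ccc(S(=O)(=O)Oc2ccccc2I)cc1` gives 3900 nM. The steps among these three stay small: a 2.8-fold lower number from compound 1 to compound 2 (0.45 log units; beyond the scatter) is modest, while a 1.5-fold lower number from compound 1 to compound 3 (0.18 log units; within the scatter) and a 1.8-fold higher number from compound 2 to compound 3 (0.27 log units; within the scatter) stay within the scatter, so the three acyl variants sit in one narrow band.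

Compound 4 `O=C(Nc1ccc(S(=O)(=O)Oc2ccccc2I)cc1)NC1CC1` differs from compound 3 by cyclopropylamino in place of 3-chloropropyl on a carbonyl carbon. Among the measured compounds shown here, none of the measured steps covers an exchange of a chain for an amino group on the carbonyl carbon; they show only that swapping chloro for butyl or ethyl along the chain moved the numbers little. Because the whole series spans no more than a 2.8-fold lower number from compound 1 to compound 2 (0.45 log units; beyond the scatter), for compound 4 the expected step in this assay is a 1.0-fold lower number from compound 3 to compound 4 (0.01 log units; within the scatter), nothing beyond the scatter. Compound 4 is therefore estimated at 7000 nM, with a range from 2500 nM to 20000 nM.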

Compound 4, half-maximal inhibitory concentration: 11000 nM
Compound 4: the middle estimate sits 1.6-fold (0.20 log units) below what was measured, within the range that was stated.
By their numbers in this assay, from the lowest: compounds 2, 3, 1 and 4 (each within the scatter of the next, the first and the last beyond it).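

In this assay the carbonyl carbon carries cyclopropylamino with no separation from the carbon chains: the exchange for 3-chloropropyl gives (a 1.5-fold higher number from compound 3 to compound 4 (0.18 log units; within the scatter)) and the exchange for pentyl gives (no change at the digits printed from compound 1 to compound 4 (within the scatter)). Only the exchange for chloromethyl goes beyond the scatter (a 2.8-fold higher number from compound 2 to compound 4 (0.45 log units; beyond the scatter)), so an amino group on this carbon leaves compound 4 in the same band as compound 1 and compound 3, while compound 2 is separated from compound 4 but not from compound 3. Nothing available explains these numbers.

Going by these compounds, it remains open whether a larger ring on the nitrogen, such as cyclohexylamino, or an open-chain group such as dimethylamino, would stay in this band. On these data alone, the effect of a carboxylic acid at the end of the chain on the carbonyl also remains open.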